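The compounds below may be only part of what the source reports. "The series", "measured", "known", "first", "only" and "open" are said of these compounds alone.

Measured so far:
Compound 1 `CCCCNc1nc(N)nc2ccn(CC(=O)NC)c12`: in an assay on HEK293 cells for agonist activity at Toll-like receptor 8 (Homo sapiens), read by a luciferase reporter, with a stated time of 6 h (a lower number here means that less compound is needed, a higher number that more compound is needed for the effect), compound 1 gives > 25 uM, a limit of the assay.
Compound 2 `CCCCNc1nc(N)nc2ccn(Cc3ccsc3)c12`: in this assay compound 2 gives > 25 uM, also a limit.
Compound 3 `CCCCNc1nc(N)nc2ccn(Cc3nccs3)c12`: in this assay compound 3 gives 2.27 uM.

Within the data shown here, compound 3 holds the only number in the set; the other two entries sit at the limit of > 25 uM in this assay, at which 2 of the 3 values shown sit. Compound 4 `CCCCNc1nc(N)nc2ccn(Cc3cccnc3)c12` differs from compound 3 by pyridin-3-yl in place of 1,3-thiazol-2-yl on a saturated chain carbon bound to an aromatic nitrogen. As far as these compounds go, the steps that touch this position are an at least 11-fold lower number from compound 1 to compound 3 (1.04 log units; beyond the scatter) and an at least 11-fold lower number from compound 2 to compound 3 (1.04 log units; beyond the scatter); both are large in the same direction, and both are bounded by the limit, so their true size is unknown. Among the measured compounds shown here, no measured step compares a six-membered ring here. The step of a 1.8-fold higher number from compound 3 to compound 4 (0.25 log units; within the scatter) is therefore expected to stay within the scatter, with a real chance of falling back to the limit. Compound 4 is estimated at 4 uM, from 1 uM to 25 uM.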

Compound 4, minimum effective concentration: > 25 uM
Compound 4: a limit, no number; the forecaster's own chance of this, stated with the estimate: 30%; middle value at least 6.2-fold (0.79 log units) from the limit.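

In this assay, a six-membered aromatic ring at this place does not keep the activity of the 1,3-thiazol-2-yl group, with pyridin-3-yl giving an at least 11-fold higher number from compound 3 to compound 4 (1.04 log units; beyond the scatter). Among these compounds, compound 3 remains the only compound with a readable number, while pyridin-3-yl joins methylcarbamoyl and thiophen-3-yl at the limit: the limit of > 25 uM in this assay, at which 3 of the 4 values shown sit. The steps among compound 1, compound 2 and compound 4 cannot be read, since both ends of each are limits.

As far as these compounds go, whether a 1,3-oxazol-2-yl or a pyridin-2-yl group on this saturated chain carbon would give a number remains open. From the compounds shown here alone, how far compound 1, compound 2 and compound 4 lie past the limit also remains open.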